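The source may hold more compounds than are shown below. What is called first, only, known or untested is meant among the compounds shown, and "the series" means these compounds.

Among the measured compounds shown here, compound 1 `CC(C)(C)C1=C(C(=O)O)N2C(=O)[C@H](CO)[C@H]2O1` gives 5 h in an ADME assay, in phosphate buffer, at 28 degrees C, at pH 7.0 (on this read-out lower numbers stand for a shorter-lived compound and higher numbers for a longer-lived compound), the lowest of the three numbers measured so far. Compound 2 `Cn1cc([C@@H](O)[C@H]2C(=O)N3C(C(=O)O)=C(C(C)(C)C)O[C@H]23)nn1` gives 6.8 h in this assay, and compound 3 `CC(C)(C)C1=C(C(=O)O)N2C(=O)[C@H]([C@H](O)CCc3ccccc3)[C@H]2O1` gives 21 h. The step of a 1.4-fold higher number from compound 1 to compound 2 (0.13 log units; within the scatter) and the step of a 4.2-fold higher number from compound 1 to compound 3 (0.62 log units; beyond the scatter) both start from compound 1 and both alter the same place that the step to compound 4 alters. The step of a 3.1-fold higher number from compound 2 to compound 3 (0.49 log units; beyond the scatter) shows how the two substituents already measured compare with one another.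

Compound 4 `CC(C)(C)C1=C(C(=O)O)N2C(=O)[C@H]([C@@H](O)c3ccc(O)cc3)[C@H]2O1` differs from compound 1 by 4-hydroxyphenyl in place of hydrogen on a saturated chain carbon bound to an oxygen on a saturated carbon and a saturated ring carbon. A ring bound to that carbon without a chain, as in compound 2, went with no change beyond the scatter, whereas the phenethyl group of compound 3 went with a modest rise. The 4-hydroxyphenyl group shares the six-membered aromatic ring of carbon only with phenethyl and the chainless attachment with the triazolyl group, so a rise is expected in this assay, smaller than that seen for compound 3 and perhaps within the scatter. The expected step is a 1.8-fold higher number from compound 1 to compound 4 (0.26 log units; within the scatter). Compound 4 is estimated at 9 h, within 4.5 h to 18 h.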

Compound 4, half-life: 10.3 h
Compound 4: the middle estimate sits 1.1-fold (0.06 log units) below what was measured; low and high end bracket the measured number.
By their numbers in this assay, from the lowest: compounds 1, 2 and 4 (each within the scatter of the next, the first and the last beyond it); then compound 3.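

In this assay the step of a 2.1-fold higher number from compound 1 to compound 4 (0.31 log units; beyond the scatter) shows that a ring bound to this saturated chain carbon without a chain can go with a modest rise beyond the scatter, which the 1-methyl-1H-1,2,3-triazol-4-yl group of compound 2 did not show. Even so, compound 2 and compound 4 lie within the scatter of each other, so this read-out does not separate the two chainless rings, and compound 4 at 10.3 h remains under compound 3 at 21 h on the printed values. No supporting measurement bears on this change.

From the compounds shown here alone, it remains open whether plain phenyl or 4-aminophenyl would give a number like that of compound 4, and where a benzyl group would fall. The compounds shown do not separate the hydroxyl on the ring from the ring itself.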